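Methyl on the piperidine ring of a pyrimidopyrazinone

The source may hold more compounds than are shown below. What is called first, only, known or untested is meant among the compounds shown, and "the series" means these compounds.

Compound 1, `CC1CCN(c2ccc(Nc3ncc4c(n3)N(C3CCCC3)CC(=O)N4)nc2)CC1`: > 30000 nM in a functional assay on MDA-MB-231 cells (Homo sapiens) for inhibition, read by MTT assay, with a stated time of 48 h; on this read-out higher numbers stand for weaker inhibition and lower numbers for stronger inhibition
Compound 2, `CN1C(=O)CN(C2CCCC2)c2nc(Nc3ccc(N4CCCCC4)cn3)ncc21`: 29300 nM in this assay

For the measured compounds named here, compound 2 gives the only real number in this assay; the other value shown is a limit. Compound 1 reaches only > 30000 nM in this assay, which is a limit of the assay and not a number, as summarised in the limit of > 30000 nM in this assay, at which 1 of the 2 values shown sits. Both compounds share a core with a cyclopentyl group and a piperidine attached to an aminopyridine; compound 1 carries a 4-methylpiperidin-1-yl group and an unsubstituted lactam nitrogen, while compound 2 has a plain piperidin-1-yl group and a methylated lactam nitrogen.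

Compound 3, `CC1CCN(c2ccc(Nc3ncc4c(n3)N(C3CCCC3)CC(=O)N4C)nc2)CC1`, combines both features. It differs from compound 2 by methyl in place of hydrogen on a saturated ring carbon. Going by the values given here, no measured step of this kind exists here, so no direction can be read from the data. The step of a 1.1-fold higher number from compound 2 to compound 3 (0.04 log units; within the scatter) is expected to fall within the usual scatter, with a lean toward weaker inhibition. Compound 3 is therefore estimated at 32000 nM in this assay, with a range from 12000 nM to 90000 nM.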

Compound 3, half-maximal inhibitory concentration: > 30000 nM
Compound 3 was reported as a limit (the forecaster's own chance of this, stated with the estimate: 55%); the middle value lies beyond the limit too.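

Going from piperidin-1-yl to 4-methylpiperidin-1-yl, with the methyl three ring bonds from the ring nitrogen, gives an at least 1.0-fold higher number from compound 2 to compound 3 (0.01 log units; that floor lies within the scatter) in this assay. From the compounds shown here alone, compound 3 gives > 30000 nM, which is a limit of the assay and not a number, so only the floor of this step is known and its true size remains open. The step between the two compounds that differ by a methyl on the amide-type nitrogen in the ring cannot be read, so that change stays undefined here, and the measurements now crowd against the top of what the assay can report: the limit of > 30000 nM in this assay, at which 2 of the 3 values shown sit.

Going by these compounds, whether a hydroxyl group, an amine or a longer chain such as ethyl in place of the methyl on that saturated ring carbon would give a clearly lower number than compound 2 at 29300 nM remains open. On these data alone, the effect of the methyl on the amide-type nitrogen also remains open, as does whether any change at either place could move this series well clear of the limit.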